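A few compounds are considered here, and "the series" means these few. Any claim that something is new, unique, unknown or untested is made for them only; others in the source may bear on it.

Measured so far, in the words of the half-life read-out:

compound 1 `O=C(NC1CCCCC1)Oc1cccc(-c2ccccc2)c1` — 0.712 h
compound 2 `O=C(NCCCCCCc1ccccc1)Oc1cccc(-c2ccccc2)c1` — 0.14 h
compound 3 `O=C(NC1CCCC1)Oc1cccc(-c2ccccc2)c1` — 0.667 h

All three were examined in an ADME assay on a cell-free system (plasma, Rattus norvegicus, strain Wistar) for metabolic stability, read by HPLC, tested at 1 uM; on this read-out higher numbers stand for a longer-lived compound and lower numbers for a shorter-lived compound. Compound 1 gives 0.712 h, the highest of the three numbers, but compound 3 stands essentially beside it: a 1.1-fold lower number from compound 1 to compound 3 (0.03 log units; within the scatter). Compound 2, which carries a long open substituent on the amide-type nitrogen rather than a ring, gives 0.14 h, clearly the shortest-lived of the set.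

Compound 4 `O=C(NC1CCC1)Oc1cccc(-c2ccccc2)c1` has not yet been measured. It differs from compound 1 in one place: cyclobutyl in place of cyclohexyl on an amide-type nitrogen. For the measured compounds named here, the only measured step that bears on this change is the one from cyclohexyl to cyclopentyl, a 1.1-fold lower number from compound 1 to compound 3 (0.03 log units; within the scatter), which lies within the usual scatter. Taking the ring smaller again, to cyclobutyl, is therefore expected to change little. The step from compound 1 to compound 4 is expected to be a 1.2-fold lower number from compound 1 to compound 4 (0.07 log units; within the scatter), no more than a slight drift downward. Compound 4 is thus estimated at 0.6 h, with a plausible range from 0.3 h to 1.2 h, and whether it actually lands there waits on the measurement.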

Compound 4, half-life in the plasma assay: 0.332 h
Estimate against measurement, compound 4: 1.8-fold (0.26 log units) above, within the range that was stated.
By their numbers in the plasma assay, from the lowest: compound 2; then compounds 4, 3 and 1 (each within the scatter of the next, the first and the last beyond it).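

The earlier step from cyclohexyl to cyclopentyl showed no readable change, so this position could have seemed indifferent to ring size, but in the plasma assay cyclobutyl brings a 2.1-fold lower number from compound 1 to compound 4 (0.33 log units; beyond the scatter), a modest change that goes beyond the scatter. The same ring also gives a 2.0-fold lower number from compound 3 to compound 4 (0.30 log units; within the scatter), so the cyclobutyl compound cannot be clearly separated from the cyclopentyl one, and the effect is only seen across the whole change from cyclohexyl to cyclobutyl. In a physicochemical assay, read by HPLC, in phosphate buffer, at pH 7.0 (a higher number here means that more of the compound is left, a lower number that less of the compound is left), compound 1 gives 41.1% and compound 4 gives 22.6%, so part of the shorter half-life of compound 4 may be due to a loss that also occurs in plain buffer, with no plasma present: the measured percent of the compound remaining of compound 1, 41.1%, and of compound 4, 22.6%, a number 18.5 percentage points lower (beyond the scatter)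

The compounds shown leave open whether a larger ring such as cycloheptyl, or a short open chain such as isopropyl, would behave like cyclohexyl or like cyclobutyl at this nitrogen. They also leave open what an oxygen inside the ring, as in tetrahydropyranyl, would do to either read-out.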